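This account rests on a few compounds, and the source may have more. Where it says the series, first, only, none or still open, it means among the compounds named here.

In a physicochemical assay for solubility, read by spectrophotometry, using the shake flask method, with a stated time of 48 h, at pH 6.5 (a higher number here means a more soluble compound, a lower number a less soluble compound), compound 1 (`O=C(O)COc1ccc2nc(-c3cn(-c4ccc(O)cc4)nn3)ccc2c1`) gives 365 ug/mL. Compound 2 (`O=C(O)Cn1ccc2ccc(-c3cn(-c4ccc(O)c(F)c4)nn3)nc2c1=O`) gives 288 ug/mL, within the usual scatter of compound 1, while compound 3 (`O=C(O)COc1ccc2nc(-c3cn(-c4ccc(O)c(F)c4)nn3)ccc2c1`) gives 37 ug/mL. Next in the series is compound 4 (`Oc1ccc(-n2cc(-c3ccc4ccccc4n3)nn2)cc1`), which has hydrogen in place of carboxymethoxy on an aromatic carbon. For the measured compounds named here, no measured step removes this group, and both compound 1 and compound 3 carry it, so there is no direct precedent. Going by the values given here, the only measured step is a 9.9-fold lower number from compound 1 to compound 3 (0.99 log units; beyond the scatter), which is beyond the scatter and comes from fluoro in place of hydrogen on an aromatic carbon. That step shows the read-out can move appreciably on a single-atom edit. The change to compound 4 removes far more, so a lower number and a step larger than that one are expected, though this remains a judgement without a matched measurement. The expected step is a 91-fold lower number from compound 1 to compound 4 (1.96 log units; beyond the scatter). For compound 4 the estimated value is 4 ug/mL, with an expected range of 0.7 ug/mL to 25 ug/mL.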

Compound 4, solubility: 2.2 ug/mL
Compound 4: the middle estimate sits 1.8-fold (0.26 log units) above what was measured; the measured number falls inside the stated range.
By their numbers in this assay, from the lowest: compound 4; then compound 3; then compounds 2 and 1 (each within the scatter of the next).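

In this assay, for the compounds shown here, removing carboxymethoxy from the aromatic carbon and leaving hydrogen gives a 170-fold lower number from compound 1 to compound 4 (2.22 log units; beyond the scatter), the first measured step at this position. This edit takes out 5 heavy atoms and is rated large, whereas the fluoro edit, a 9.9-fold lower number from compound 1 to compound 3 (0.99 log units; beyond the scatter), is rated modest. No measurement on hand explains the size of this step.

The compounds shown do not separate the carboxylic acid end of the group from the ether oxygen that links it to the core, so a methoxy or hydroxy at this carbon would be the informative comparison. From the compounds shown here alone, whether a longer chain ending in a carboxylic acid, or an aminoethoxy group, would hold the read-out near that of compound 1 also remains open.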